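Removing a sugar from two related acetylated terpenoids

The source may report more compounds than this note shows. Statements on the series, on what has been measured and on what is new or still open speak of the compounds shown alone.

Measured in a functional assay on K562 cells (Homo sapiens) for cytotoxicity, read by spectrophotometry; a lower number here means a stronger inhibitor, a higher number a weaker inhibitor:
Compound 1 `CC(=O)O[C@@H](C[C@@H]1C(C)=CCC(=O)C1(C)C)/C(C)=C/[C@H](O)C/C=C(\C)CC[C@H]1C(C)(C)[C@@H](O[C@@H]2O[C@H](CO)[C@H](O)[C@H](O)[C@H]2O)CC[C@]1(C)OC(C)=O` gives > 100000 nM, a limit and not a number.
Compound 2 `CC(=O)O[C@@H](C[C@@H]1C(C)=CCC(=O)C1(C)C)/C(C)=C/[C@H](O)C/C=C(\C)CC[C@H]1C(C)(C)[C@@H](O)CC[C@]1(C)OC(C)=O` gives 14600 nM.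
Compound 3 `CC(=O)O[C@@]1(C)CC[C@H](O[C@@H]2O[C@H](CO)[C@H](O)[C@H](O)[C@H]2O)C(C)(C)[C@@H]1CC/C(C)=C/C[C@@H](O)/C=C(\C)C(=O)C[C@H]1C(C)(C)C(=O)C=C[C@]1(C)O` gives > 100000 nM, again only a limit.

Compounds 1 and 2 differ by one change, (hydrogen in place of 3,4,5-trihydroxy-6-(hydroxymethyl)oxan-2-yl on an oxygen on a saturated carbon), which produced an at least 6.8-fold lower number from compound 1 to compound 2 (0.83 log units; beyond the scatter). That step is known only as a bound because of the limit of > 100000 nM in this assay, at which 2 of the 3 values shown sit. Compound 4 `CC(=O)O[C@@]1(C)CC[C@H](O)C(C)(C)[C@@H]1CC/C(C)=C/C[C@@H](O)/C=C(\C)C(=O)C[C@H]1C(C)(C)C(=O)C=C[C@]1(C)O` is not yet measured; it stands to compound 3 as compound 2 stands to compound 1, through the same change (hydrogen in place of 3,4,5-trihydroxy-6-(hydroxymethyl)oxan-2-yl on an oxygen on a saturated carbon). How the core of compound 3 differs from the core of compound 1 is not broken down here. The step of an at least 3.3-fold lower number from compound 3 to compound 4 (0.52 log units; beyond the scatter) is expected to resemble the earlier one. Compound 4 is therefore expected near 30000 nM, most likely between 8000 nM and 100000 nM, with a real chance that this assay again reports only a limit. That expectation rests on compound 2 having given 14600 nM after the same change.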

Compound 4, half-maximal inhibitory concentration: 18900 nM
Compound 4: the middle estimate sits 1.6-fold (0.20 log units) above what was measured; measured number inside the range.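

Removing the 3,4,5-trihydroxy-6-(hydroxymethyl)oxan-2-yl group, which leaves a hydroxy in its place, again lowers the number in this assay, with an at least 5.2-fold lower number from compound 3 to compound 4 (0.72 log units; beyond the scatter). The change therefore points the same way on both cores, and the two steps can be set side by side: the same change on two cores in this assay, an at least 6.8-fold lower number (0.83 log units; beyond the scatter) from compound 1 to compound 2 and an at least 5.2-fold lower number (0.72 log units; beyond the scatter) from compound 3 to compound 4; the limit leaves it open whether they differ. On these data alone, their true sizes remain unknown, and it cannot be said whether the change has an equal effect on each core, because both sugar-bearing compounds give only a limit: the limit of > 100000 nM in this assay, at which 2 of the 4 values shown sit.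

The compounds shown leave open what would happen if that oxygen carried a group other than the sugar or hydrogen, such as a chain ending in an amine or a carboxylic acid. They also leave open whether such a replacement would behave alike on both cores.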